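The source may hold more compounds than are shown below. What is called first, only, known or untested is meant among the compounds shown, and "the series" means these compounds.

Notes on the series. Two compounds carry measurements. Compound 1 `CC(C)OC(=O)/C=C/c1ccccc1` gives 2% in a functional assay on the whole organism for inhibition, with Brassica rapa subsp. chinensis as the target, with a stated time of 3 days, tested at 100 ppm; a lower number here means less inhibition of growth, a higher number more inhibition of growth at the concentration tested. Compound 2 `CC(C)CNC(=O)/C=C/c1ccccc1` gives 78% in this assay. Going by the values given here, compound 2 thus stands highest of the two numbers, and the only step between measured compounds, a number 76 percentage points higher from compound 1 to compound 2 (beyond the scatter), is the one that bears on what follows.

Compound 3 `CCCCOC(=O)/C=C/c1ccccc1` differs from compound 2 by butoxy in place of isobutylamino on a carbonyl carbon. Among the compounds with values here, this change reverses the earlier one in kind: the amino link on the carbonyl carbon gives way again to an oxy link, and the one measured step across such a change was large. A large fall in this assay is therefore expected, a step of roughly a number 68 percentage points lower from compound 2 to compound 3 (beyond the scatter), bringing compound 3 back near compound 1. Compound 3 is estimated at 10%, with a range from 0% to 35%.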

Compound 3, percent growth inhibition at one concentration: 0%
Beside the measured number, compound 3's estimate is 10 percentage points above it; low and high end bracket the measured number.
By their numbers in this assay, from the lowest: compounds 3 and 1 (each within the scatter of the next); then compound 2.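

With butoxy in place of isobutylamino on a carbonyl carbon, this assay shows a number 78 percentage points lower from compound 2 to compound 3 (beyond the scatter) and thus a second large step between an amino link and an oxy link, now with a straight chain on the oxygen. Among the oxy-linked compounds, butyl in place of isopropyl on an oxygen next to a carbonyl group gives a number 2 percentage points lower from compound 1 to compound 3 (within the scatter) and so leaves the number essentially unchanged, which sets compound 2 apart from both compound 1 and compound 3. Nothing available explains the gap between the two kinds of link.

The amino side still rests on compound 2 alone, so butylamino and isopropylamino on the same carbonyl carbon would show how much the chain on the nitrogen counts. Going by these compounds, a carboxylic acid or an unsubstituted amide in this place also remains open.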